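Series notes on a chloro to nitro change

The source may hold more compounds than are shown below. What is called first, only, known or untested is meant among the compounds shown, and "the series" means these compounds.

Measured so far:
Compound 1, `COc1ccc(Oc2ccc([N+](=O)[O-])cc2-c2ccsc2S(=O)(=O)N2CCN(C(=S)Nc3ccc(Cl)cc3)CC2)cc1OC`, in a functional assay on HL-60 cells (Homo sapiens) for inhibition, read by CCK-8 assay, with a stated time of 48 h (on this read-out lower numbers stand for stronger inhibition and higher numbers for weaker inhibition), gives > 50000 nM, which is a limit of the assay.
Compound 2, `COc1ccc(Oc2ccc([N+](=O)[O-])cc2-c2ccsc2S(=O)(=O)N2CCN(C(=S)Nc3ccc([N+](=O)[O-])cc3)CC2)cc1OC`, in this assay gives > 50000 nM, again a limit of the assay.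
Compound 3, `O=S(=O)(c1sccc1-c1ccccc1Oc1ccc(O)c(O)c1)N1CCN(C(=S)Nc2ccc(Cl)cc2)CC1`, in this assay gives 5500 nM.

From compound 1 to compound 2 the change is nitro in place of chloro on an aromatic carbon. The step is a step that the two limits leave unreadable from compound 1 to compound 2, its size hidden because both values sit at the limit of > 50000 nM in this assay, at which 2 of the 3 values shown sit. Among the compounds with values here, compound 3 carries a different core from compound 1; the difference between the two cores is not broken down here, so no step between them can be read.

Compound 4, `O=[N+]([O-])c1ccc(NC(=S)N2CCN(S(=O)(=O)c3sccc3-c3ccccc3Oc3ccc(O)c(O)c3)CC2)cc1`, is not yet measured. It differs from compound 3 by nitro in place of chloro on an aromatic carbon, the same change already seen from compound 1 to compound 2, at a place described in the same words. That earlier step gives no usable size, so the expectation rests on compound 3 alone and its value of 5500 nM. The step expected is a 1.3-fold higher number from compound 3 to compound 4 (0.10 log units; within the scatter), within the usual scatter. Compound 4 is estimated at 7000 nM, between 2500 nM and 25000 nM.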

Compound 4, half-maximal inhibitory concentration: 5300 nM
Compound 4: middle estimate off by 1.3-fold (0.12 log units), on the high side; measured number inside the range.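

On the core of compound 3 in this assay, nitro in place of chloro gives a 1.0-fold lower number from compound 3 to compound 4 (0.02 log units; within the scatter), so 4-chlorophenyl and 4-nitrophenyl cannot be told apart on this core. On the core of compound 1 the same change cannot be read, so no size is available to compare between the two cores: the limit of > 50000 nM in this assay, at which 2 of the 4 values shown sit. This leaves one readable step on one core, which does not show that the two cores respond alike to the change, nor that the change would be without effect on the core of compound 1.

The compounds shown leave open whether an amine, a carboxylic acid or a longer chain on the same aromatic carbon would also stay within the scatter of compound 3 and compound 4. They also leave open which of the differences between the two cores matters for the read-out.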